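The source may hold more compounds than are shown below. What is called first, only, known or untested is meant among the compounds shown, and "the series" means these compounds.

Measured so far in a functional assay on HCT-116 cells (Homo sapiens) for cytotoxicity, read by sulforhodamine B assay, with a stated time of 48 h, tested at 0.001 uM; on this read-out lower numbers stand for a stronger effect and higher numbers for a weaker effect at the one concentration tested:

compound 1, `COc1cc(C)cc(-c2nn(CC#N)cc2-c2ccc(-c3cccc(C(C)=O)c3)nc2)c1`: 101%
compound 2, `Cc1cc(O)cc(-c2nn(CC#N)cc2-c2ccnc(-c3ccc(Oc4ccccc4)cc3)c2)c1`: 95%

Both measured compounds share one core and both leave the cells essentially untouched at the single concentration tested. In this assay compound 1 gives 101%. In this assay compound 2 gives 95%. Among the measured compounds shown here, of the two numbers, that of compound 2 is the smaller, but its only neighbour, compound 1, sits a gap away that lies inside the scatter, so the two compounds cannot be told apart on this read-out.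

Compound 3, `Cc1cc(O)cc(-c2nn(CC#N)cc2-c2ccnc(-c3ccc(N(C)C)cc3)c2)c1`, has not yet been measured. It differs from compound 2 in one place: dimethylamino in place of phenoxy on an aromatic carbon. For the measured compounds named here, no measured pair in this set shows what such an exchange does, so there is no step on record from which a direction could be read. With compound 2 already at the inactive end of the scale, the expectation is a step of no size beyond the scatter, a number 2 percentage points higher from compound 2 to compound 3 (within the scatter), in either direction. Compound 3 is therefore estimated at 97%, with a range from 85% to 110%.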

Compound 3, a percentage reported as activity, at one concentration (the size of the read-out at that concentration, not a potency): 95%
Beside the measured number, compound 3's estimate is 2 percentage points above it, within the range that was stated.
By their numbers in this assay, from the lowest: compounds 2, 3 and 1 (each within the scatter of the next).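

In this assay, among the compounds shown here, dimethylamino in place of phenoxy on an aromatic carbon gives no change at the digits printed from compound 2 to compound 3 (within the scatter), which is the first step on record at this position. For the compounds shown here, the place, on a six-membered aromatic ring of carbon only and para to a large group, can therefore hold either phenoxy, with its carbon ring and 7 heavy atoms, or dimethylamino, with no ring and 3 heavy atoms, with no difference visible on this read-out at the one concentration tested; as both compounds lie at the inactive end of the scale, this shows only that neither group brings out an effect there, not that the two groups are equivalent under other conditions. No independent measurement is at hand that would account for this result.

The compounds shown leave open whether a carboxylic acid, a primary amine or a longer alkyl chain at the same place would move the number out of the scatter. They also leave open whether compound 2 and compound 3 would separate at higher concentrations, where a single reading at this low dose gives no information.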